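Swapping Thiophene for Furan on a Pyridine-Linked Diphenol

The source may hold more compounds than are shown below. What is called first, only, known or untested is meant among the compounds shown, and "the series" means these compounds.

Three compounds share one core, a six-membered ring with one nitrogen carrying two hydroxyphenyl groups and a five-membered ring. Compound 1 `Oc1ccccc1-c1cc(-c2cccs2)cc(-c2ccccc2O)n1` and compound 2 `Oc1cccc(-c2cc(-c3cccs3)cc(-c3ccccc3O)n2)c1` differ only in where the hydroxyl sits on one phenyl, and compound 3 `Oc1ccc(-c2cc(-c3cccs3)cc(-c3cccc(O)c3)n2)cc1` moves it once more. In a functional assay on HeLa cells (Homo sapiens) for cytotoxicity, read by CCK-8 assay (a higher number here means a weaker inhibitor, a lower number a stronger inhibitor), compound 1 gives only a limit, > 50000 nM. In this assay compound 2 likewise gives only a limit, > 50000 nM. Compound 3 gives a number, 4140 nM. The step from compound 1 to compound 2 is a step that the two limits leave unreadable from compound 1 to compound 2, while an at least 12-fold lower number from compound 2 to compound 3 (1.08 log units; beyond the scatter). Both measured values that are limits sit at the limit of > 50000 nM in this assay, at which 2 of the 3 values shown sit.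

Compound 4 `Oc1cccc(-c2cc(-c3ccco3)cc(-c3ccccc3O)n2)c1` keeps everything of compound 2 except the five-membered ring: furan-2-yl in place of thiophen-2-yl on an aromatic carbon. Neither measured step touches this ring; both move a hydroxyl on a phenyl, so nothing measured here speaks for or against a change in this assay from this swap. Because compound 2 shows only a limit, > 50000 nM, compound 4 is expected to stay near that same limit, with a step that the limit leaves unreadable from compound 2 to compound 4 expected to lie within the scatter. Compound 4 is therefore estimated at 60000 nM, between 15000 nM and 250000 nM.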

Compound 4, half-maximal inhibitory concentration: > 50000 nM
Compound 4 ended at the assay's limit; the forecaster's own chance of this, stated with the estimate: 75%; the middle value lies beyond the limit too.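

No step can be read from compound 2 to compound 4, because both compounds give only a limit rather than a number: the limit of > 50000 nM in this assay, at which 3 of the 4 values shown sit.

The compounds shown leave open whether furan-2-yl in place of thiophen-2-yl would change the result in this assay on a compound with a readable value, such as compound 3.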